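Removing the Fluorine: From Compound 2 to Compound 4

The compounds below may be only part of what the source reports. "The series", "measured", "known", "first", "only" and "open" are said of these compounds alone.

Three compounds sharing one core have been tested in a functional assay on MGC-803 cells (Homo sapiens) for inhibition, read by sulforhodamine B assay; on this read-out higher numbers stand for weaker inhibition and lower numbers for stronger inhibition:

Compound 1 `O=C1C(Nc2ccc(I)cc2)=CC(=O)c2c1nc1n2[C@H]2OC[C@@H](O)[C@H]2OC1` gives 2150 nM.
Compound 2 `O=C1C=C(Nc2cccc(F)c2)C(=O)c2c1nc1n2[C@H]2OC[C@@H](O)[C@H]2OC1` gives 2180 nM.
Compound 3 `CCOc1ccc(NC2=CC(=O)c3c(nc4n3[C@H]3OC[C@@H](O)[C@H]3OC4)C2=O)cc1` gives 2090 nM.

The three results lie very close together. Compound 2 sits within the usual scatter of both compound 1 and compound 3, so nothing separates the three on this read-out. For the measured compounds named here, the only single-point comparison among them, a 1.0-fold lower number from compound 1 to compound 3 (0.01 log units; within the scatter), swaps one group on the six-membered aromatic ring for another and leaves the number essentially where it was.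

Compound 4 `O=C1C=C(Nc2ccccc2)C(=O)c2c1nc1n2[C@H]2OC[C@@H](O)[C@H]2OC1` has not yet been measured. It differs from compound 2 by hydrogen in place of fluoro on an aromatic carbon. Going by the values given here, no measured step touches the fluoro group, so there is no direct precedent. Among the compounds with values here, what is known is that the single step from iodo to ethoxy changed nothing beyond the scatter, and that all three measured compounds, each carrying a different group on its six-membered aromatic ring, land at the same level. The expected step, a 1.0-fold higher number from compound 2 to compound 4 (0.00 log units; within the scatter), is therefore within the scatter, with no clear direction. Compound 4 is estimated at 2200 nM, with a likely range from 1100 nM to 4400 nM in this assay.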

Compound 4, half-maximal inhibitory concentration: 1730 nM
The estimate for compound 4 lay 1.3-fold (0.10 log units) above the measured number; low and high end bracket the measured number.
By their numbers in this assay, from the lowest: compounds 4, 3, 1 and 2 (each within the scatter of the next).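

In this assay, replacing the fluoro of the 3-fluorophenyl group with hydrogen, which leaves a plain phenyl, gives a 1.3-fold lower number from compound 2 to compound 4 (0.10 log units; within the scatter), so this change does not move the result beyond the usual scatter. For the compounds shown here, this is the first measured step at this position, and it adds something the earlier compounds could not show: compound 4 has no substituent on this ring, and it still lands at the same level, so on this read-out the fluoro is not needed to reach that level. No measurement shown here offers an explanation for this outcome.

The compounds shown leave open whether any group on this ring can shift the number beyond the scatter, for example an amine or a carboxylic acid in the place the fluoro occupied. They also leave open whether the shared core responds more strongly than this ring does, for example if its hydroxyl group were replaced by a methoxy group.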